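This account rests on a few compounds, and the source may have more. Where it says the series, first, only, none or still open, it means among the compounds named here.

Three compounds share one core and differ only in the group attached to a sulfur. Compound 1 `CC(C)c1n[nH]c2c(NCc3ccc(-c4ccccn4)cc3)nc(SCCCN(C)C)nc12` gives 105 nM in a functional assay on HT cells (Homo sapiens) for antiproliferative activity, read by fluorescence, with a stated time of 72 h; a lower number here means a stronger inhibitor of growth, a higher number a weaker inhibitor of growth. Compound 3 `CC(C)c1n[nH]c2c(NCc3ccc(-c4ccccn4)cc3)nc(SCC(C)(C)N)nc12` gives 85 nM in this assay. Compound 2 `CC(C)c1n[nH]c2c(NCc3ccc(-c4ccccn4)cc3)nc(SCCNC(=N)N)nc12` gives 390 nM in this assay, the highest of the three numbers: the steps of a 3.7-fold higher number from compound 1 to compound 2 (0.57 log units; beyond the scatter) and a 4.6-fold lower number from compound 2 to compound 3 (0.66 log units; beyond the scatter) both lie beyond the scatter, whereas a 1.2-fold lower number from compound 1 to compound 3 (0.09 log units; within the scatter) does not. Compound 4 `CC(C)c1n[nH]c2c(NCc3ccc(-c4ccccn4)cc3)nc(SC3CCCCC3N)nc12` has not yet been measured. It differs from compound 2 in one place: a group of 7 heavy atoms (6 carbon, 1 nitrogen; one six-membered non-aromatic ring of carbon only) in place of a group of 6 heavy atoms (3 carbon, 3 nitrogen; no ring), on a sulfur. The step that bears most on this is a 4.6-fold lower number from compound 2 to compound 3 (0.66 log units; beyond the scatter), where the same departing group gave way to a group carrying a single amine, and a 3.7-fold higher number from compound 1 to compound 2 (0.57 log units; beyond the scatter) points the same way, the amine-bearing chain giving the lower number. Because the step of a 4.6-fold lower number from compound 2 to compound 3 (0.66 log units; beyond the scatter) shows such a replacement by an amine-bearing group giving the lower number, a modest drop is expected for compound 4, a 3.5-fold lower number from compound 2 to compound 4 (0.55 log units; beyond the scatter). Compound 4 is therefore estimated at 110 nM in this assay, with a likely range from 40 nM to 300 nM.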

Compound 4, concentration for 50% growth inhibition: 139 nM
The estimate for compound 4 lay 1.3-fold (0.10 log units) below the measured number, and the stated range covers the measured number.
By their numbers in this assay, from the lowest: compounds 3, 1 and 4 (each within the scatter of the next); then compound 2.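

In this assay, 2-aminocyclohexyl on the sulfur also gives a lower number than the group in compound 2 (a 2.8-fold lower number from compound 2 to compound 4 (0.45 log units; beyond the scatter)), so this drop is not confined to open chains and also occurs with a six-membered non-aromatic ring of carbon only. The ring does not set compound 4 apart from the chain compounds (a 1.6-fold higher number from compound 3 to compound 4 (0.21 log units; within the scatter); a 1.3-fold higher number from compound 1 to compound 4 (0.12 log units; within the scatter)): both steps lie within the scatter, leaving compound 2 as the only one apart from the rest. No measurement shown here explains these numbers.

Every group shown on the sulfur carries nitrogen, so the role of the amine itself remains open. A plain cyclohexyl or a 2-hydroxycyclohexyl group in the same place would address that question.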